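Amine exchange on the shared core: cytotoxicity outlook

The source may hold more compounds than are shown below. What is called first, only, known or untested is meant among the compounds shown, and "the series" means these compounds.

Compound 1 `Cc1nc(NCc2ccco2)c2cnn(-c3ccccc3)c2n1` and compound 2 `Cc1nc(Nc2ccccc2)c2cnn(-c3ccccc3)c2n1` share the core. In a functional assay on G-361 cells (Homo sapiens) for cytotoxicity, read by sulforhodamine B assay (a lower number here means that less compound is tolerated, a higher number that more compound is tolerated), compound 1 gives > 100000 nM, a limit of the assay. In this assay compound 2 gives > 100000 nM, likewise a limit. The step that the two limits leave unreadable from compound 1 to compound 2 is thus not readable; both values sit at the limit of > 100000 nM in this assay, at which 2 of the 2 values shown sit. Compound 3 `CCN(CC)c1nc(C)nc2c1cnn2-c1ccccc1` differs from compound 2 by diethylamino in place of anilino on an aromatic carbon. For the measured compounds named here, no measured step bears on this change, and compound 2 stands only at a limit, so nothing beyond the scatter is expected in this assay. Compound 3 is expected at 150000 nM, with a range from 50000 nM to 400000 nM. This implies the expected step that the limit leaves unreadable from compound 2 to compound 3.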

Compound 3, concentration lethal to 50% of the cells: > 100000 nM
Compound 3: only a limit was reported; the forecaster's own chance of this, stated with the estimate: 75%; the middle value does not contradict the limit.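

In this assay, for the compounds shown here, compound 3 gives > 100000 nM, a limit of the assay, so no step linking it to compound 1 or compound 2 can be read. On these data alone, whether any amine on the shared core gives a readable value remains open.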